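From trifluoromethyl to ethoxy on the aryl amine

This account rests on a few compounds, and the source may have more. Where it says the series, first, only, none or still open, it means among the compounds named here.

In a functional assay on MGC-803 cells (Homo sapiens) for inhibition, read by sulforhodamine B assay (a lower number here means a stronger inhibitor, a higher number a weaker inhibitor), compound 1 `O=C1C(NC2CCCC2)=CC(=O)c2c1nc1n2[C@H]2OC[C@@H](O)[C@H]2OC1`, with cyclopentyl on the amine nitrogen, gives only a limit, > 16000 nM. Going by the values given here, compound 2 `O=C1C(Nc2ccc(C(F)(F)F)cc2)=CC(=O)c2c1nc1n2[C@H]2OC[C@@H](O)[C@H]2OC1` gives 1860 nM, the only actual number so far. Compound 3 `CCOc1ccc(NC2=CC(=O)c3c(nc4n3[C@H]3OC[C@@H](O)[C@H]3OC4)C2=O)cc1` carries ethoxy in place of trifluoromethyl on an aromatic carbon, para to a large group: ethoxy in place of trifluoromethyl on an aromatic carbon. Among the compounds with values here, the one measured step, an at least 8.6-fold lower number from compound 1 to compound 2 (0.93 log units; beyond the scatter), rests on the limit of > 16000 nM in this assay, at which 1 of the 2 values shown sits, and replaces the whole amine substituent, so it does not test this exchange. Only a small change, in no firm direction, is therefore expected: a 1.1-fold higher number from compound 2 to compound 3 (0.03 log units; within the scatter). For compound 3 the estimated value is 2000 nM, with an expected range of 650 nM to 6500 nM.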

Compound 3, half-maximal inhibitory concentration: 2090 nM
For compound 3 the middle estimate is 1.0-fold (0.02 log units) below the measured one, within the range that was stated.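

The exchange on the aromatic carbon, para to a large group, gives a 1.1-fold higher number from compound 2 to compound 3 (0.05 log units; within the scatter) in this assay and so does not separate trifluoromethyl from ethoxy at this position. A second aryl amine, 4-ethoxyphenyl, also stands apart from cyclopentyl, with an at least 7.6-fold lower number from compound 1 to compound 3 (0.88 log units; beyond the scatter) as the step. The size of that step stays open-ended, since compound 1 gives only a limit: the limit of > 16000 nM in this assay, at which 1 of the 3 values shown sits.

As far as these compounds go, whether an amine or a carboxylic acid on that aromatic carbon, or a chain longer than ethoxy, would shift the number stays open. So does the true distance of compound 1 from the two aryl amines.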